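The source may hold more compounds than are shown below. What is called first, only, known or untested is meant among the compounds shown, and "the series" means these compounds.

Measured compounds in a functional assay on HeLa cells (Homo sapiens) for inhibition, read by MTT assay, with a stated time of 48 h; on this read-out lower numbers stand for stronger inhibition and higher numbers for weaker inhibition:
- compound 1 `CCOC(=O)C1=C(N/C=N/c2nnc(S(N)(=O)=O)s2)Nc2[nH]nc(C)c2C1c1ccc(N(C)C)cc1`: 26300 nM
- compound 2 `CCOC(=O)C1=C(NN=C(C#N)C#N)Nc2[nH]nc(C)c2C1c1ccc(N(C)C)cc1`: 15200 nM

Compound 1 sits at the top of these two numbers, yet the step of a 1.7-fold lower number from compound 1 to compound 2 (0.24 log units; within the scatter) is within the scatter, so compound 1 and compound 2 cannot be told apart on this assay.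

Compound 3 `CCOC(=O)C1=C(N/C=N/c2ccc(C)cc2)Nc2[nH]nc(C)c2C1c1ccc(N(C)C)cc1` is the next compound, not yet measured. Its change from compound 1 is 4-methylphenyl in place of 5-sulfamoyl-1,3,4-thiadiazol-2-yl on a double-bonded nitrogen. For the measured compounds named here, the only measured step that bears on it is the one from compound 1 to compound 2, where the whole group on the amine nitrogen, including the 5-sulfamoyl-1,3,4-thiadiazol-2-yl ring, was exchanged, and the number barely moved: a 1.7-fold lower number from compound 1 to compound 2 (0.24 log units; within the scatter). Exchanging the same ring for 4-methylphenyl is therefore expected to give no step beyond the scatter, in either direction.

Compound 3 is estimated at 22000 nM in this assay, with a range from 7000 nM to 70000 nM. This estimate means an expected step of a 1.2-fold lower number from compound 1 to compound 3 (0.08 log units; within the scatter).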

Compound 3, half-maximal inhibitory concentration: 43200 nM
Estimate against measurement, compound 3: 2.0-fold (0.29 log units) below; low and high end bracket the measured number.
By their numbers in this assay, from the lowest: compounds 2, 1 and 3 (each within the scatter of the next, the first and the last beyond it).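

In this assay, 4-methylphenyl in place of 5-sulfamoyl-1,3,4-thiadiazol-2-yl on a double-bonded nitrogen gives a 1.6-fold higher number from compound 1 to compound 3 (0.22 log units; within the scatter) and so leaves the two compounds indistinguishable, even though a ring of carbon only, with no hydrogen-bond donors or acceptors, has replaced the sulfamoyl-bearing ring. The first difference beyond the scatter appears when the groups on the amine nitrogen are compared, with a 2.8-fold higher number from compound 2 to compound 3 (0.45 log units; beyond the scatter) being a modest step, so the group at this place can move the number, though not by much so far. No measurement shown gives a reason for this difference.

Going by these compounds, it remains open how a carboxylic acid or an amine in place of the methyl of 4-methylphenyl would read. On these data alone, it is also open whether any group at this place can bring the number well below that of compound 2.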